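Swapping chloro for fluoro on compound 1

A few compounds are considered here, and "the series" means these few. Any claim that something is new, unique, unknown or untested is made for them only; others in the source may bear on it.

In a functional assay on HL-60 cells (Homo sapiens) for inhibition, read by MTT assay, with a stated time of 72 h (on this read-out higher numbers stand for weaker inhibition and lower numbers for stronger inhibition), compound 1 (`Cc1ccc(C)c(N2CCN(C(=O)c3oc(C)nc3-c3cccc(Cl)c3)CC2)c1`) gives 345 nM and so holds the higher of the two numbers available. Compound 2 (`COc1cccc(N2CCN(C(=O)c3oc(C)nc3-c3ccc(F)cc3)CC2)c1`) gives 112 nM as its nearest neighbour, a lower number by more than the usual scatter. Compound 3 (`COc1cccc(-c2nc(C)oc2C(=O)N2CCN(c3cccc(Cl)c3)CC2)c1`) is reported as "not active" (no number reported) and has no number at all.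

Compound 4 (`Cc1ccc(C)c(N2CCN(C(=O)c3oc(C)nc3-c3cccc(F)c3)CC2)c1`) has not yet been measured. It departs from compound 1 by a single exchange: fluoro in place of chloro on an aromatic carbon (fluoro in place of chloro on an aromatic carbon, meta to a large group), so that 3-chlorophenyl becomes 3-fluorophenyl. Within the data shown here, no measured pair isolates this exchange, which leaves the expectation on thin ground. Compound 2, which also bears a fluoro group, reaches 112 nM in this assay but differs from compound 1 elsewhere too. Compound 3 with its "not active" (no number reported) result is a reminder that a number is not guaranteed in this series. In this assay the estimated step is a 1.2-fold lower number from compound 1 to compound 4 (0.06 log units; within the scatter) and it is expected to stay within the scatter, leaning slightly toward stronger inhibition. For compound 4 the estimate is 300 nM with an expected range from 100 nM to 900 nM in this measurement.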

Compound 4, half-maximal inhibitory concentration: 204 nM
Compound 4: the middle estimate sits 1.5-fold (0.17 log units) above what was measured; the range from low to high includes it.
By their numbers in this assay, from the lowest: compounds 2, 4 and 1 (each within the scatter of the next, the first and the last beyond it).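

In this assay, among these compounds, the step from 3-chlorophenyl to 3-fluorophenyl gives the first reading of a single exchange at this position: a 1.7-fold lower number from compound 1 to compound 4 (0.23 log units; within the scatter) with the rest of the structure held fixed. The earlier compounds shown here differ from one another in more than one place, so none of them could isolate this aromatic carbon or separate the halogen from the other changes, whereas this pair shows that fluoro and chloro at this position cannot be told apart on this read-out, and that a number is retained when the halogen is exchanged on the core of compound 1. Nothing available accounts for this result or gives a reason for it.

The compounds shown leave open whether the same position would keep a number with a group of another kind, such as an amine, a carboxylic acid or a nitrile, in place of the halogen. They also leave open whether the exchange of chloro for fluoro would give a step of similar size on a compound with a different substitution pattern elsewhere in the series.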